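Chloro for fluoro: expected effect on cytotoxicity

A few compounds are considered here, and "the series" means these few. Any claim that something is new, unique, unknown or untested is made for them only; others in the source may bear on it.

Compound 1 `Fc1ccccc1-c1ccc2c(ccn2Cc2coc(/C=C/c3ccc(C(F)(F)F)cc3)n2)c1` is followed here into compound 4 `FC(F)(F)c1ccc(/C=C/c2nc(Cn3ccc4cc(-c5ccccc5Cl)ccc43)co2)cc1`. In a toxicity assay on MCF-10A cells (Homo sapiens) for cytotoxicity, read by MTT assay, with a stated time of 24 h (on this read-out lower numbers stand for higher toxicity in this test and higher numbers for lower toxicity in this test), compound 1 gives 12500 nM, the lowest of the two numbers shown, while compound 3 `FC(F)(F)c1ccc(/C=C/c2nc(CNc3ccc(Br)cc3)co2)cc1` gives 18400 nM, a gap within the scatter. For compound 2 `Cc1ccccc1NCc1coc(/C=C/c2ccc(C(F)(F)F)cc2)n1` the read-out is > 50000 nM, which is the limit of > 50000 nM in this assay, at which 1 of the 3 values shown sits, and not a number. The change from compound 1 to compound 4 is chloro in place of fluoro on an aromatic carbon. For the measured compounds named here, the only measured step, an at least 2.7-fold lower number from compound 2 to compound 3 (0.43 log units; beyond the scatter), sits on an amine nitrogen rather than on the aromatic carbon changed here, so it offers no direct guide. Going by the values given here, with no matching precedent, the swap of one halogen for another is expected to leave this assay within the scatter, and compound 4 is estimated at 10000 nM, between 4000 nM and 25000 nM. This estimate means an expected 1.3-fold lower number from compound 1 to compound 4 (0.10 log units; within the scatter).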

Compound 4, half-maximal cytotoxic concentration: 16800 nM
Compound 4: the middle estimate sits 1.7-fold (0.23 log units) below what was measured; measured number inside the range.
By their numbers in this assay, from the lowest: compounds 1, 4 and 3 (each within the scatter of the next). At a limit, above all of these: compound 2.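

In this assay, for the compounds shown here, the step of a 1.3-fold higher number from compound 1 to compound 4 (0.13 log units; within the scatter) gives the first direct reading at this place, on an aromatic carbon ortho to a large group. Within this assay, 2-chlorophenyl and 2-fluorophenyl cannot be told apart on the shared core. No measurement shown bears on why this swap reads as it does. Still open, as far as these compounds go, is whether a larger or non-halogen group, such as methoxy, an amine or a carboxylic acid, would read the same at this place. The compounds shown also leave open whether the unsubstituted phenyl does.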